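A few compounds are considered here, and "the series" means these few. Any claim that something is new, unique, unknown or untested is made for them only; others in the source may bear on it.

Working notes on the sulfonyl series. Three compounds share one core and differ only in the group on the sulfonyl sulfur. Compound 1 `O=C(NCc1ccc(S(=O)(=O)C2CCC(F)(F)CC2)cc1)N1Cc2ccncc2C1` carries 4,4-difluorocyclohexyl there; in an assay on isolated protein for inhibition of Nicotinamide phosphoribosyltransferase (Homo sapiens), read by mass spectrometry, with stated times of 15 min and 30 min (a lower number here means a stronger inhibitor, a higher number a weaker inhibitor), compound 1 gives 78 nM. Compound 2 `O=C(NCc1ccc(S(=O)(=O)C2CCCOC2)cc1)N1Cc2ccncc2C1` carries oxan-3-yl and in this assay compound 2 gives 44 nM; the step of a 1.8-fold lower number from compound 1 to compound 2 (0.25 log units; within the scatter) stays within the scatter. Compound 3 `O=C(NCc1ccc(S(=O)(=O)N2CCC[C@@H](O)C2)cc1)N1Cc2ccncc2C1` carries 3-hydroxypiperidin-1-yl and in this assay compound 3 gives 28 nM, the lowest of the three numbers; the step of a 2.8-fold lower number from compound 1 to compound 3 (0.44 log units; beyond the scatter) is beyond the scatter, while the step of a 1.6-fold lower number from compound 2 to compound 3 (0.20 log units; within the scatter) is not.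

Compound 4 `CN1CCN(S(=O)(=O)c2ccc(CNC(=O)N3Cc4ccncc4C3)cc2)CC1` is not yet measured. Its difference from compound 3 is 4-methylpiperazin-1-yl in place of 3-hydroxypiperidin-1-yl on a sulfonyl sulfur. The three measured steps all change the group on the sulfonyl sulfur and bear on it by place, but none of them brings in 4-methylpiperazin-1-yl; the largest of them is a 2.8-fold lower number from compound 1 to compound 3 (0.44 log units; beyond the scatter), the other two lie within the scatter. The expectation is therefore a step of no more than modest size in this assay, with no clear direction, as a 1.4-fold higher number from compound 3 to compound 4 (0.15 log units; within the scatter). Compound 4 is estimated at 40 nM, expected to fall between 15 nM and 120 nM.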

Compound 4, half-maximal inhibitory concentration: 38 nM
Compound 4: middle estimate off by 1.1-fold (0.02 log units), on the high side; measured number inside the range.
By their numbers in this assay, from the lowest: compounds 3, 4, 2 and 1 (each within the scatter of the next, the first and the last beyond it).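

In this assay, 4-methylpiperazin-1-yl in place of 3-hydroxypiperidin-1-yl on the sulfonyl sulfur gives a 1.4-fold higher number from compound 3 to compound 4 (0.13 log units; within the scatter), so neither the hydrogen-bond donor nor the defined stereocentre of the leaving group is required for a number in this range. Set against the other two groups, 4-methylpiperazin-1-yl gives a 1.2-fold lower number from compound 2 to compound 4 (0.06 log units; within the scatter) and a 2.1-fold lower number from compound 1 to compound 4 (0.31 log units; beyond the scatter), which makes it the second group, after 3-hydroxypiperidin-1-yl, to stand beyond the scatter from 4,4-difluorocyclohexyl, while oxan-3-yl does not. No measurement is at hand that would account for these steps.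

Going by these compounds, it stays open what an unsubstituted piperidin-1-yl, a morpholin-4-yl or an open-chain dimethylamino group would give on the sulfonyl sulfur, and so whether the hydroxyl of compound 3 or the methyl of compound 4 contributes anything on its own. The opposite stereoisomer of compound 3 and a group carrying a carboxylic acid are also open, and the four compounds shown set no limit on how large a step this place can produce.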